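Chlorophenyl position swap on two hydrazide cores

This account rests on a few compounds, and the source may have more. Where it says the series, first, only, none or still open, it means among the compounds named here.

Compound 1 `O=C(NNC(=O)c1ccccc1Cl)c1ccc(NS(=O)(=O)c2cnc(O)nc2O)cc1` and compound 3 `O=C(NNC(=O)c1ccccc1NS(=O)(=O)c1cnc(O)nc1O)c1ccccc1Cl` are built from the same atoms joined differently; the difference between the two cores is not broken down here. In a functional assay on MDA-MB-231 cells (Homo sapiens) for antiproliferative activity, read by MTT assay, with a stated time of 24 h (a higher number here means a weaker inhibitor, a lower number a stronger inhibitor), compound 1 gives 13900 nM, and compound 3 gives 8310 nM; these two numbers lie within the scatter of each other. Compound 2 `O=C(NNC(=O)c1cccc(Cl)c1)c1ccc(NS(=O)(=O)c2cnc(O)nc2O)cc1` carries the change (3-chlorophenyl in place of 2-chlorophenyl on a carbonyl carbon), and in this assay compound 2 gives 4160 nM, a step of a 3.3-fold lower number from compound 1 to compound 2 (0.52 log units; beyond the scatter). Compound 4 `O=C(NNC(=O)c1ccccc1NS(=O)(=O)c1cnc(O)nc1O)c1cccc(Cl)c1` is not yet measured; it carries the change (3-chlorophenyl in place of 2-chlorophenyl on a carbonyl carbon), the same change at the same place. For compound 4 a step of a 3.0-fold lower number from compound 3 to compound 4 (0.47 log units; beyond the scatter) in this assay is expected, resting on the one earlier occurrence, a 3.3-fold lower number from compound 1 to compound 2 (0.52 log units; beyond the scatter). The estimate for compound 4 in this assay is 2800 nM, with a range from 1000 nM to 7500 nM, kept wide because a 3.3-fold lower number from compound 1 to compound 2 (0.52 log units; beyond the scatter) is the only support.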

Compound 4, half-maximal inhibitory concentration: 4420 nM
Compound 4: the middle estimate sits 1.6-fold (0.20 log units) below what was measured, within the range that was stated.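

On the core of compound 3, 3-chlorophenyl in place of 2-chlorophenyl gives, in this assay, a 1.9-fold lower number from compound 3 to compound 4 (0.27 log units; within the scatter), so this step alone cannot be separated from repeat variation. Set beside the step on the other core, it does not differ measurably: the same change on two cores in this assay, a 3.3-fold lower number (0.52 log units; beyond the scatter) from compound 1 to compound 2 and a 1.9-fold lower number (0.27 log units; within the scatter) from compound 3 to compound 4, 1.8-fold (0.25 log units) apart, within the scatter of two such steps This fits the change carrying over between these two cores, but it rests on only two pairs, one within the scatter, and does not show an effect on the core of compound 3 or predict the step on any further core.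

Still open, going by these compounds, is whether a methoxy group, a nitrile or an amine in place of the chlorine would behave alike on both cores.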